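The source may report more compounds than this note shows. Statements on the series, on what has been measured and on what is new or still open speak of the compounds shown alone.

Measured compounds:
Compound 1 `O=c1c(C2N=C(c3ccccc3)SS2)coc2ccc(Cl)cc12` gives 52700 nM in a functional assay on PC-3 cells (Homo sapiens) for inhibition, read by sulforhodamine B assay, with a stated time of 48 h; a lower number here means a stronger inhibitor, a higher number a weaker inhibitor.
Compound 2 `O=c1c(C2N=C(c3ccccc3)SS2)coc2cc(Cl)c(Cl)cc12` gives 60000 nM in this assay.

Within the data shown here, compound 1 stands lowest of the two numbers, with compound 2 as its only neighbour; the two are within the scatter of each other, so no order between them can be read. Among the measured compounds shown here, the one measured step, a 1.1-fold higher number from compound 1 to compound 2 (0.06 log units; within the scatter), adds a second chloro and does not move the number beyond the scatter.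

Compound 3 `O=c1c(C2N=C(c3ccccc3)SS2)coc2ccccc12` is the unmeasured member: hydrogen in place of chloro on an aromatic carbon. For the measured compounds named here, no measured step removes a chloro from this part of the shared core, but the step from compound 1 to compound 2 shows that a chloro on this ring is without clear effect in this assay. The expected step of a 1.0-fold higher number from compound 1 to compound 3 (0.02 log units; within the scatter) is therefore none beyond the scatter. Compound 3 is estimated at 55000 nM in this assay, with a range from 25000 nM to 120000 nM.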

Compound 3, half-maximal inhibitory concentration: > 100000 nM
Compound 3: only a limit was reported; the forecaster's own chance of this, stated with the estimate: 10%; at least 1.8-fold (0.25 log units) between middle value and limit.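

Compound 3 gives > 100000 nM in this assay, and this is a limit of the assay, not a number. The earlier step only added a second chloro to the ring, whereas this change removes the sole chloro, with hydrogen in its place, and gives an at least 1.8-fold higher number from compound 1 to compound 3 (0.27 log units; that floor lies within the scatter), so the reading runs in one direction only, yet its floor does not separate hydrogen from chloro at this position. The limit is also the only one in the series: the limit of > 100000 nM in this assay, at which 1 of the 3 values shown sits.

The compounds shown leave open how far the step runs past its floor, and so whether the chloro on this aromatic carbon matters beyond the scatter. They also leave open whether another group at this carbon, such as an amine or a carboxylic acid, would give a lower number than chloro.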